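The compounds below may be only part of what the source reports. "The series", "measured", "known", "first", "only" and "open" are said of these compounds alone.

Notes on the series. Compound 1 `Cc1cc(NCc2ccccn2)n2ncc(-c3ccc(N(C)C)cc3)c2n1` carries the shared core with a 4-(dimethylamino)phenyl group. In a physicochemical assay for solubility, read by HPLC, using the shake flask method, measured as kinetic solubility, with a stated time of 2 h, at pH 7.4 (a lower number here means a less soluble compound, a higher number a more soluble compound), compound 1 gives only a limit, < 5000 nM, and not a number. Compound 2 `Cc1cc(NCc2ccccn2)n2ncc(-c3ccc(C(=O)Nc4ccccc4)cc3)c2n1` differs in one place, phenylcarbamoyl in place of dimethylamino on an aromatic carbon, and in this assay compound 2 gives 5000 nM. The step of a number no lower from compound 1 to compound 2 (the limit leaves the size open) is therefore open in size, since compound 1 sits at the limit of < 5000 nM in this assay, at which 1 of the 2 values shown sits.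

Compound 3 `Cc1cc(NCc2ccccn2)n2ncc(-c3cncnc3)c2n1` is not yet measured. It differs from compound 1 as follows: pyrimidin-5-yl in place of 4-(dimethylamino)phenyl on an aromatic carbon. Among the measured compounds shown here, no measured step covers this change; the step from compound 1 to compound 2 alters a different group and, with compound 1 at a limit, gives no readable size, so nothing in the data fixes the direction or size for compound 3. The estimate rests on compound 1 alone at < 5000 nM, taken as a limit, and on compound 2 at 5000 nM. For compound 3 the expected value in this assay is 10000 nM, with a range from 3000 nM to 40000 nM. The step from compound 1 to compound 3 is expected to be an at least 2.0-fold higher number from compound 1 to compound 3 (0.30 log units; that floor lies within the scatter), though a limit reading for compound 3 remains possible.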

Compound 3, solubility: 111000 nM
Compound 3: the middle estimate sits 11-fold (1.05 log units) below what was measured; measured number outside the range, above it.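

Among the compounds shown here, at this position, on an aromatic carbon of a five-membered aromatic ring with 2 nitrogen, the earlier compounds gave no readable size for any change, whereas in this assay pyrimidin-5-yl in place of 4-(dimethylamino)phenyl gives an at least 22-fold higher number from compound 1 to compound 3 (1.34 log units; beyond the scatter). Compound 1 is read only as a limit, so this size is a floor and the true gap may be larger, while the step from compound 1 to compound 2 cannot be read in size at all: the limit of < 5000 nM in this assay, at which 1 of the 3 values shown sits. This single change removes the dimethylamino group and the carbon-only ring together and brings in a six-membered aromatic ring with 2 hetero atoms, so one step holds several differences at once.

Which of these differences carries the step stays open, and a plain phenyl or a pyridin-3-yl at this position would begin to separate them. Also open, as far as these compounds go, is whether the step holds when the pyrimidin-5-yl itself bears an amine or a longer chain, or when the rest of the core of compound 3 is altered.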